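A few compounds are considered here, and "the series" means these few. Any claim that something is new, unique, unknown or untested is made for them only; others in the source may bear on it.

Three compounds of this series have been run in a functional assay on the whole organism (strain albino) for inhibition, with Rattus norvegicus as the target, read by paw edema, with stated times of 30 min and 3 h, at a dose of 50 mg/kg by the oral route; a higher number here means more inhibition at the dose given (going by the name of the read-out), a lower number less inhibition. Compound 1 `O=C(O)CCC(=O)/C=C/c1cn(-c2ccccc2)nc1-c1ccc(Cl)cc1` gives 6.32% in this assay, and compound 2 `Cc1ccc(-c2nn(-c3ccccc3)cc2/C=C/C(=O)CCC(=O)O)cc1` gives 11.5%. Between them stands the change (methyl in place of chloro on an aromatic carbon), which made a number 5.2 percentage points higher from compound 1 to compound 2 (within the scatter). Compound 3 `CC(=O)Nc1ccc(OC(=O)c2cn(-c3ccccc3)nc2-c2ccc(Cl)cc2)cc1` rests on a different core and gives 16.7%; how the core of compound 3 differs from the core of compound 1 is not broken down here. Compound 3 lies beyond the scatter from compound 1 and within the scatter of compound 2. Compound 4 `CC(=O)Nc1ccc(OC(=O)c2cn(-c3ccccc3)nc2-c2ccc(C)cc2)cc1` has not yet been measured in this assay. It carries the change (methyl in place of chloro on an aromatic carbon), the same change as between compound 1 and compound 2, at the same place. That earlier step was a number 5.2 percentage points higher from compound 1 to compound 2 (within the scatter). Resting on that, the expected step is a number 3.3 percentage points higher from compound 3 to compound 4 (within the scatter). Compound 4 is estimated at 20%, between 8% and 32%.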

Compound 4, a percentage reported as inhibition, in the whole organism at one dose (the size of the read-out at that dose, not a potency): 6.32%
The estimate for compound 4 lay 13.7 percentage points above the measured number, outside the stated range (below it).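

In this assay, the change from 4-chlorophenyl to 4-methylphenyl comes out as a number 10.4 percentage points lower from compound 3 to compound 4 (beyond the scatter). The step seen on the core of compound 1 therefore does not carry over to the core of compound 3: the same change on two cores in this assay, a number 5.2 percentage points higher (within the scatter) from compound 1 to compound 2 and a number 10.4 percentage points lower (beyond the scatter) from compound 3 to compound 4, 15.6 percentage points apart, beyond the scatter of two such steps. This rests on a single pair on each core at one dose, and it shows neither why the two cores part nor how the change would read on a third core.

The compounds shown leave open whether other groups at this place, such as fluoro, methoxy or an amine, would also part between the two cores. They also leave open whether the two cores would part with a longer chain in place of methyl.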